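Swapping chloro for methoxy on a weakly active scaffold

This account rests on a few compounds, and the source may have more. Where it says the series, first, only, none or still open, it means among the compounds named here.

Compound 1 `CCOC(=O)c1nn(-c2ccc([N+](=O)[O-])cc2)/c(=N/c2nc(-c3c(C)n(C)n(-c4ccccc4)c3=O)cs2)s1` is tested in a functional assay on HepG2 cells (Homo sapiens) for cytotoxicity, read by sulforhodamine B assay, with a stated time of 72 h (a higher number here means a weaker inhibitor, a lower number a stronger inhibitor), and gives 8110 nM. Compound 2 `Cc1c(-c2csc(/N=C3\S/C(=C\c4ccc(Cl)cc4)C(=O)N3c3ccccc3)n2)c(=O)n(-c2ccccc2)n1C` shares part of this framework, but in this assay compound 2 returns only a limit, > 100000 nM. That boundary, (the limit of > 100000 nM in this assay, at which 1 of the 2 values shown sits), is the whole of what is known about where compound 2 stands: no number, only a limit. Compound 3 `COc1ccc(/C=C2\S/C(=N\c3nc(-c4c(C)n(C)n(-c5ccccc5)c4=O)cs3)N(c3ccccc3)C2=O)cc1` differs from compound 2 in one place, (methoxy in place of chloro on an aromatic carbon), that is, methoxy in place of chloro on an aromatic carbon. No measured pair among these compounds shows what such a swap does in this assay, so there is nothing to set the size of the step from. The expected step is a number no higher from compound 2 to compound 3 (the limit leaves the size open), nothing beyond the usual scatter, and quite possibly again only a limit. Compound 3 is therefore estimated at 100000 nM, within a range from 30000 nM to 300000 nM.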

Compound 3, half-maximal inhibitory concentration: 13200 nM
The estimate for compound 3 lay 7.6-fold (0.88 log units) above the measured number; measured number outside the range, below it.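

In this assay, replacing 4-chlorophenyl with 4-methoxyphenyl gives an at least 7.5-fold lower number from compound 2 to compound 3 (0.87 log units; beyond the scatter). Within the data shown here, this is the first sign that the group at this place on the six-membered aromatic ring matters: one swap turns a limit into a measured number. The full size of the step stays unknown, as compound 2 gives a limit and not a number: the limit of > 100000 nM in this assay, at which 1 of the 3 values shown sits.

The compounds shown leave open whether the step depends on methoxy in particular or would follow from other replacements of chloro, such as a hydroxyl, an amine or a longer ether like ethoxy at the same place. They also leave open whether the same swap would bring a similar step on a different framework.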